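A small polar chain in place of methoxyphenyl

The source may hold more compounds than are shown below. What is called first, only, known or untested is meant among the compounds shown, and "the series" means these compounds.

Compound 1 `O=C1O[C@H]([C@@H](O)Cn2cc(-c3cccc(O)c3)nn2)C(OCc2ccccc2)=C1OCc1ccccc1` gives 39300 nM in a functional assay on HeLa cells (Homo sapiens) for antiproliferative activity, read by MTT assay, with a stated time of 72 h; on this read-out higher numbers stand for weaker inhibition and lower numbers for stronger inhibition. Compound 3 `C[Si](C)(C)c1cn(C[C@H](O)[C@H]2OC(=O)C(OCc3ccccc3)=C2OCc2ccccc2)nn1` gives 22300 nM in this assay. Compound 2 `COc1ccccc1-c1cn(C[C@H](O)[C@H]2OC(=O)C(OCc3ccccc3)=C2OCc2ccccc2)nn1` reaches only a limit in this assay, > 100000 nM, the weakest reading among the three, as the limit of > 100000 nM in this assay, at which 1 of the 3 values shown sits, shows.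

Compound 4 `O=C1O[C@H]([C@@H](O)Cn2cc(CCO)nn2)C(OCc2ccccc2)=C1OCc1ccccc1` keeps the core of compound 2 and changes one group: 2-hydroxyethyl in place of 2-methoxyphenyl on an aromatic carbon. The step of an at least 4.4-fold lower number from compound 2 to compound 3 (0.65 log units; beyond the scatter) also replaced the 2-methoxyphenyl with a small group without a ring, and an at least 2.5-fold higher number from compound 1 to compound 2 (0.40 log units; beyond the scatter) shows the 2-methoxyphenyl as the poorer group. A step of similar size, towards a lower number, is therefore expected, an at least 3.3-fold lower number from compound 2 to compound 4 (0.52 log units; beyond the scatter). Compound 4 is estimated at 30000 nM, in a range from 10000 nM to 100000 nM.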

Compound 4, half-maximal inhibitory concentration: 68800 nM
Compound 4: the middle estimate sits 2.3-fold (0.36 log units) below what was measured; measured number inside the range.
By their numbers in this assay, from the lowest: compounds 3, 1 and 4 (each within the scatter of the next, the first and the last beyond it). At a limit, above all of these: compound 2.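

Compound 2 reads only as a limit of the assay: the limit of > 100000 nM in this assay, at which 1 of the 4 values shown sits. Read as a floor, an at least 1.4-fold lower number from compound 2 to compound 4 (0.16 log units; that floor lies within the scatter) proves no gain, while a 3.1-fold higher number from compound 3 to compound 4 (0.49 log units; beyond the scatter) shows that not every small group without a ring gives the same reading at this aromatic carbon. With a 1.8-fold higher number from compound 1 to compound 4 (0.24 log units; within the scatter), 2-hydroxyethyl and 3-hydroxyphenyl cannot be told apart, so an aromatic ring at this position is not needed for a reading in this range. As far as these compounds go, whether the hydroxyl itself counts stays open: a plain ethyl chain, an amine or a carboxylic acid in its place would tell.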